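The compounds below may be only part of what the source reports. "The series", "measured", "known", "first", "only" and "open" are said of these compounds alone.

Measured so far in a toxicity assay on MT4 cells (Homo sapiens) for cytotoxicity, read by MTT assay; a higher number here means that more compound is tolerated, a lower number that less compound is tolerated:
- compound 1 `Cc1cc(-c2ccccc2Cl)cc(C)c1Oc1cc(N)nc(Nc2ccc(C#N)cc2)n1`: 25100 nM
- compound 2 `Cc1cc(-c2ccccc2C#N)cc(C)c1Oc1cc(N)nc(Nc2ccc(C#N)cc2)n1`: 25400 nM

In this assay, compound 2 stands at 25400 nM, level with compound 1 within the scatter, so neither stands apart on these two numbers.

The next compound is compound 3 `Cc1cc(-c2ccccc2C#N)ccc1Oc1cc(N)nc(Nc2ccc(C#N)cc2)n1`, which carries hydrogen in place of methyl on an aromatic carbon. The carbon is ortho to a large group, meta to a 2-cyanophenyl group and meta to a methyl group.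

Among the measured compounds shown here, only one measured step is available: a 1.0-fold higher number from compound 1 to compound 2 (0.01 log units; within the scatter). It is cyano in place of chloro on an aromatic carbon, a different kind of change, so it bears on this one only indirectly. For the measured compounds named here, no measured pair shows the loss of a methyl. The flat step from chloro to cyano gives no sign that this tolerance moves readily, so no change beyond the scatter is expected, though the range must stay wide.

The estimated step is a 1.3-fold lower number from compound 2 to compound 3 (0.10 log units; within the scatter). For compound 3 the expected value in this assay is 20000 nM, with an estimated range of 7000 nM to 55000 nM.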

Compound 3, half-maximal cytotoxic concentration: 28600 nM
Beside the measured number, compound 3's estimate is 1.4-fold (0.16 log units) below it, within the range that was stated.
By their numbers in this assay, from the lowest: compounds 1, 2 and 3 (each within the scatter of the next).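

In this assay, hydrogen in place of methyl on the aromatic carbon ortho to a large group gives a 1.1-fold higher number from compound 2 to compound 3 (0.05 log units; within the scatter), so compound 3 stays level with compound 2 and this methyl group is not needed to keep the tolerated concentration at this level in this pair. Among the compounds shown here, this is the first measured step at this position, and it adds a second kind of change to the cyano-for-chloro change, which gives a 1.0-fold higher number from compound 1 to compound 2 (0.01 log units; within the scatter); both single-place changes in this small set lie within the scatter. No measured information is available that would explain the flat result at this position.

Going by these compounds, it remains open whether a larger or more functional group on the same carbon, such as ethyl, methoxy or an amine, would stay level with compound 2 and compound 3 or would shift the tolerated concentration beyond the scatter. Also open, on these data alone, is whether the remaining methyl group, meta to the carbon changed here, can be replaced by hydrogen with an equally flat result, and whether the same holds with chloro in place of the cyano on the 2-cyanophenyl group.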